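A few compounds are considered here, and "the series" means these few. Any claim that something is new, unique, unknown or untested is made for them only; others in the source may bear on it.

Values in a functional assay on PC-3 cells (Homo sapiens) for cytotoxicity, read by sulforhodamine B assay, with a stated time of 48 h; on this read-out higher numbers stand for weaker inhibition and lower numbers for stronger inhibition:
- compound 1 `COc1ccc(C2=NO[C@]3(C2)C(=O)O[C@@H]2[C@H]3CC[C@H](C)[C@]3(O)C=CC(=O)[C@@]23C)cc1`: 35000 nM
- compound 2 `C[C@H]1CC[C@@H]2[C@@H](OC(=O)[C@]23CC(c2ccc(Cl)cc2)=NO3)[C@]2(C)C(=O)C=C[C@@]12O`: 49000 nM
- compound 3 `C[C@H]1CC[C@@H]2[C@@H](OC(=O)[C@]23CC(c2ccccc2Br)=NO3)[C@]2(C)C(=O)C=C[C@@]12O`: 51000 nM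

In this assay, compound 3 cannot be separated from the other two, as the steps show: a 1.0-fold higher number from compound 2 to compound 3 (0.02 log units; within the scatter) and a 1.5-fold higher number from compound 1 to compound 3 (0.16 log units; within the scatter). The next compound is compound 4 `C[C@H]1CC[C@@H]2[C@@H](OC(=O)[C@]23CC(c2ccc(N(C)C)cc2)=NO3)[C@]2(C)C(=O)C=C[C@@]12O`, and the change is 4-(dimethylamino)phenyl in place of 2-bromophenyl on a carbon with a double bond to nitrogen. The closest evidence is these two exchanges of the same aromatic group, together with a 1.4-fold higher number from compound 1 to compound 2 (0.15 log units; within the scatter). Among the compounds with values here, all three stay within the scatter, although no compound with a dimethylamino group has been measured yet. The expected result is therefore no real change, with a 1.3-fold lower number from compound 3 to compound 4 (0.11 log units; within the scatter). The estimate for compound 4 is 40000 nM, with an expected range of 15000 nM to 90000 nM.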

Compound 4, half-maximal inhibitory concentration: 6300 nM
Beside the measured number, compound 4's estimate is 6.3-fold (0.80 log units) above it, and the stated range ends above it.
By their numbers in this assay, from the lowest: compound 4; then compounds 1, 2 and 3 (each within the scatter of the next).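

In this assay, the group on this carbon with a double bond to nitrogen can shift the number beyond the scatter: 4-(dimethylamino)phenyl in place of 2-bromophenyl gives stronger inhibition (an 8.1-fold lower number from compound 3 to compound 4 (0.91 log units; beyond the scatter)). Within the data shown here, on the aromatic carbon, dimethylamino also separates from chloro (a 7.8-fold lower number from compound 2 to compound 4 (0.89 log units; beyond the scatter)) and from methoxy (a 5.6-fold lower number from compound 1 to compound 4 (0.74 log units; beyond the scatter)), two groups that the earlier compounds could not separate from each other. Nothing available explains this shift. Still open, on these data alone, is whether the change depends on dimethylamino itself or extends to other nitrogen groups, such as a primary amine or morpholine, on that aromatic carbon.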